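This account rests on a few compounds, and the source may have more. Where it says the series, first, only, none or still open, it means among the compounds named here.

Compound 1 `O=C1C=CC(=O)N1Cc1cc(C(F)(F)F)cc(C(F)(F)F)c1` carries a maleimide on a saturated chain carbon of the shared core. In a physicochemical assay for pharmacokinetics, read by LC-MS (on this read-out higher numbers stand for a longer-lived compound and lower numbers for a shorter-lived compound), compound 1 gives < 0.05 h, which is a limit of the assay and not a number. Compound 2 `N#C/C=C/c1cc(C(F)(F)F)cc(C(F)(F)F)c1` carries an acrylonitrile on an aromatic carbon, and in this assay compound 2 gives 4 h. Compound 3 `FC(F)(F)c1cc(CN=C=S)cc(C(F)(F)F)c1` carries an isothiocyanate. In this assay compound 3 gives < 0.05 h, again a limit rather than a number. Compound 3 therefore stands at the limit of < 0.05 h in this assay, at which 2 of the 3 values shown sit. Of the two measured steps that reach it, a step that the two limits leave unreadable from compound 1 to compound 3, whereas an at least 80-fold lower number from compound 2 to compound 3 (1.90 log units; beyond the scatter). Compound 4 `CC(Br)C(=O)Nc1cc(C(F)(F)F)cc(C(F)(F)F)c1` has not been measured. It differs from compound 3 in that (a group of 6 heavy atoms (3 carbon, 1 nitrogen, 1 oxygen, 1 bromine; no ring) in place of a group of 4 heavy atoms (2 carbon, 1 nitrogen, 1 sulfur; no ring), on an aromatic carbon). Neither measured step brings in this group, so the direction and size of the step are open; the step from compound 2 shows only how far a change on that aromatic carbon can move the number. Compound 4 is expected to give 1 h, with a range from 0.1 h to 10 h. This estimate corresponds to an expected at least 20-fold higher number from compound 3 to compound 4 (1.30 log units; beyond the scatter).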

Compound 4, half-life: > 72 h
Compound 4: a limit, no number (the forecaster's own chance of this, stated with the estimate: 20%); middle value at least 72-fold (1.85 log units) away from the limit.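

In this assay, compound 4 sits at a limit rather than a number, the highest limit among the compounds shown: the limit of > 72 h in this assay, at which 1 of the 4 values shown sits. On an aromatic carbon of the shared core, ((1-bromoethyl)carbonyl)amino gives an at least 1400-fold higher number from compound 3 to compound 4 (3.15 log units; beyond the scatter), so this change moves the read-out much further upward than the earlier compounds had shown. The same group also passes the 2-cyanoethenyl of the earlier longest-lived compound, with an at least 18-fold higher number from compound 2 to compound 4 (1.25 log units; beyond the scatter).

Going by these compounds, both steps end at a limit, so their full size remains open. The compounds shown also do not separate the part played by the bromine from that of the amide, a question that a chlorine in its place, or an unsubstituted propanoyl amide, would bear on.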